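A few compounds are considered here, and "the series" means these few. Any claim that something is new, unique, unknown or untested is made for them only; others in the source may bear on it.

Within the data shown here, compound 2 `CCCCCc1cc(C(F)(F)F)ccc1CNC(=O)C(C)c1ccc(NS(C)(=O)=O)c(F)c1` stands with the lower of the two numbers so far in an assay on CHO cells for antagonist activity at transient receptor potential cation channel subfamily V member 1 (Homo sapiens), read by FLIPR; on this read-out lower numbers stand for stronger inhibition and higher numbers for weaker inhibition: in this assay compound 2 gives 0.4 nM. The other measured compound, compound 1 `CCC1CCN(c2cc(C(F)(F)F)ccc2CNC(=O)C(C)c2ccc(NS(C)(=O)=O)c(F)c2)CC1`, gives 0.7 nM in this assay, and a 1.8-fold lower number from compound 1 to compound 2 (0.24 log units; within the scatter), so the two cannot be told apart on these data. Compound 3 `COc1cc(OC)cc(-c2cc(C(F)(F)F)ccc2CNC(=O)C(C)c2ccc(NS(C)(=O)=O)c(F)c2)c1` is not yet measured. It differs from compound 2 in one place: 3,5-dimethoxyphenyl in place of pentyl on an aromatic carbon. Among the measured compounds shown here, the only measured step touches the same aromatic carbon, where a saturated ring was exchanged for a chain (a 1.8-fold lower number from compound 1 to compound 2 (0.24 log units; within the scatter)), and it stayed within the scatter. For the measured compounds named here, no measured step speaks to an aromatic ring bearing two methoxy groups at this carbon, so the expectation is a step of modest size at most, in either direction. Compound 3 is expected to show a 2.5-fold higher number from compound 2 to compound 3 (0.40 log units; beyond the scatter). Compound 3 is therefore estimated at 1 nM in this assay, with a range from 0.3 nM to 4 nM.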

Compound 3, inhibition constant: 5.8 nM
The estimate for compound 3 lay 5.8-fold (0.76 log units) below the measured number; the whole stated range lies below it.
By their numbers in this assay, from the lowest: compounds 2 and 1 (each within the scatter of the next); then compound 3.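

In this assay the aromatic carbon ortho to a large group and meta to a trifluoromethyl group proves not to be indifferent to what it carries: 3,5-dimethoxyphenyl gives a 15-fold higher number from compound 2 to compound 3 (1.16 log units; beyond the scatter) and an 8.3-fold higher number from compound 1 to compound 3 (0.92 log units; beyond the scatter) in the same direction. Pentyl and 4-ethylpiperidin-1-yl could not be told apart, but both stand on the side of stronger inhibition relative to this aromatic ring, the first group at this carbon to shift the number beyond the scatter. Nothing available explains the size of this step.

Going by these compounds, whether the loss belongs to the aromatic ring itself or to its two methoxy groups stays open, and a plain phenyl or a cyclohexyl at this carbon would separate the two. On these data alone, how a chain longer than pentyl or a primary amine would fare here also remains open.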